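Swapping methyl for fluoro on a nitro-bearing dienone scaffold

The source may report more compounds than this note shows. Statements on the series, on what has been measured and on what is new or still open speak of the compounds shown alone.

Compound 1 `Cc1ccc(/C=C2\CCC/C(=C\c3cccc([N+](=O)[O-])c3)C2=O)cc1` and compound 3 `O=C1/C(=C/c2ccc(F)cc2)CCC/C1=C\c1cccc([N+](=O)[O-])c1` share one core, and compound 2 `Cc1ccc(/C=C2\CCC/C(=C\c3ccc([N+](=O)[O-])cc3)C2=O)cc1` carries a second core that differs from the first in how the same atoms are joined; the difference between the two cores is not broken down here. All three were tested in a functional assay on CCRF-CEM cells (Homo sapiens) for cytotoxicity, with a stated time of 72 h; a lower number here means a stronger inhibitor, a higher number a weaker inhibitor. In this assay compound 1 gives 10100 nM, compound 2 gives 8530 nM, and compound 3 gives 5050 nM.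

Compound 3 arises from compound 1 by one change, (fluoro in place of methyl on an aromatic carbon), and this produced a 2.0-fold lower number from compound 1 to compound 3 (0.30 log units; within the scatter). Compound 4 `O=C1/C(=C/c2ccc(F)cc2)CCC/C1=C\c1ccc([N+](=O)[O-])cc1` has not yet been measured. It arises from compound 2 by fluoro in place of methyl on an aromatic carbon, the same change at the same kind of place, only on the second core.

Within the data shown here, for compound 4 the step expected from this change is a 1.9-fold lower number from compound 2 to compound 4 (0.28 log units; within the scatter), resting on the single earlier instance in compound 1 and compound 3 and on the value of compound 2. Compound 4 is therefore estimated at 4500 nM, with a plausible range from 2000 nM to 10000 nM.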

Compound 4, half-maximal inhibitory concentration: 18600 nM
Beside the measured number, compound 4's estimate is 4.1-fold (0.62 log units) below it, outside the stated range (above it).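

In this assay, fluoro in place of methyl gave a 2.2-fold higher number from compound 2 to compound 4 (0.34 log units; beyond the scatter), so on this core the swap from 4-methylphenyl to 4-fluorophenyl made the compound a modestly weaker inhibitor. Set beside the earlier case, the same change did not carry over unchanged from one core to the other: the same change on two cores in this assay, a 2.0-fold lower number (0.30 log units; within the scatter) from compound 1 to compound 3 and a 2.2-fold higher number (0.34 log units; beyond the scatter) from compound 2 to compound 4, 4.4-fold (0.64 log units) apart, beyond the scatter of two such steps. This shows that, in these two pairs, the result of the swap depended on the core, but with only two instances, one of them within the scatter, it neither explains the gap nor tells what the swap would do on a third core.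

The compounds shown leave open whether a chloro, a methoxy or an amine at the place held by methyl and fluoro would also behave differently on the two cores. They also leave open which feature of the difference between the two cores goes with the gap.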